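The source may report more compounds than this note shows. Statements on the series, on what has been measured and on what is new or still open speak of the compounds shown alone.

Among the measured compounds shown here, in a functional assay on K-562R cells (Homo sapiens) for cytotoxicity, read by XTT assay, with a stated time of 24 h (a lower number here means a stronger inhibitor, a higher number a weaker inhibitor), three related compounds have numbers so far. Compound 1 `Cc1ccc(NC(=O)c2ccc(Br)cc2OCCCCn2ccnc2)cc1Nc1nccc(-c2cccnc2)n1` gives 44600 nM, compound 2 `Cc1ccc(NC(=O)c2ccc([N+](=O)[O-])c(OCCCCn3ccnc3)c2)cc1Nc1nccc(-c2cccnc2)n1` gives 47600 nM, and compound 3 `Cc1ccc(NC(=O)c2ccc(OCCCCn3ccnc3)c(Br)c2)cc1Nc1nccc(-c2cccnc2)n1` gives 31800 nM. Compound 3 therefore stands within the usual scatter of both others, and the three cannot be ranked. Compound 4 `Cc1ccc(NC(=O)c2ccc(OCCCCn3ccnc3)c(I)c2)cc1Nc1nccc(-c2cccnc2)n1` differs from compound 3 in one place: iodo in place of bromo on an aromatic carbon, with iodo in place of bromo on an aromatic carbon. For the measured compounds named here, no measured pair shows this kind of swap, so the data offer no direct guide. No change beyond the scatter is expected in this assay, and neither direction is favoured. The expected change is small, a 1.1-fold lower number from compound 3 to compound 4 (0.03 log units; within the scatter). Compound 4 is estimated at 30000 nM, with an expected range of 14000 nM to 60000 nM.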

Compound 4, half-maximal inhibitory concentration: 52400 nM
Beside the measured number, compound 4's estimate is 1.7-fold (0.24 log units) below it, within the range that was stated.
By their numbers in this assay, from the lowest: compounds 3, 1, 2 and 4 (each within the scatter of the next).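

In this assay, among the compounds shown here, iodo in place of bromo on this aromatic carbon, ortho to the 4-(1H-imidazol-1-yl)butoxy group, gives the first one-place comparison (a 1.6-fold higher number from compound 3 to compound 4 (0.22 log units; within the scatter)). Compound 3 and compound 4 cannot be told apart, so at this position the swap between these two halogens shows no readable effect. Nothing available here bears on this result. Still open, from the compounds shown here alone, is whether an amine or a carboxylic acid on this carbon would move the number beyond the scatter. A longer chain in place of the 4-(1H-imidazol-1-yl)butoxy group is equally untested by the compounds shown.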